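Cytotoxicity of fused bicyclic compounds on CCRF-CEM cells

This account rests on a few compounds, and the source may have more. Where it says the series, first, only, none or still open, it means among the compounds named here.

Measured compounds:
compound 1, `Cc1ccc(-c2nc3sc(Cc4ccc(Cl)cc4)nn3c2C=O)cc1`, 17000 nM
compound 2, `O=Cc1c(-c2ccc(Cl)cc2Cl)nc2sc(Cc3ccc(Cl)cc3)nn12`, 79000 nM
compound 3, `Cc1ccc(-c2nc3sc(Cc4ccc(Cl)cc4)nn3c2SC#N)cc1`, 22000 nM

Three compounds were tested in an ADME assay on CCRF-CEM cells (Homo sapiens) for cytotoxicity, with a stated time of 72 h; on this read-out higher numbers stand for weaker inhibition and lower numbers for stronger inhibition. Compound 1 gives 17000 nM in this assay. Compound 2 carries the change 2,4-dichlorophenyl in place of 4-methylphenyl on an aromatic carbon and gives 79000 nM, a step of a 4.6-fold higher number from compound 1 to compound 2 (0.67 log units; beyond the scatter). Compound 3 differs from compound 1 by cyanosulfanyl in place of formyl on an aromatic carbon. In this assay compound 3 gives 22000 nM, a step of a 1.3-fold higher number from compound 1 to compound 3 (0.11 log units; within the scatter).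

Compound 4, `N#CSc1c(-c2ccc(Cl)cc2Cl)nc2sc(Cc3ccc(Cl)cc3)nn12`, has not yet been measured. It differs from compound 3 by 2,4-dichlorophenyl in place of 4-methylphenyl on an aromatic carbon. Within the data shown here, this is the same kind of change as the one from compound 1 to compound 2, but the place is not identical: in the earlier pair the carbon sits next to the ring atom that bears a formyl group, in the new pair next to the ring atom that bears a cyanosulfanyl group. Because a 4.6-fold higher number from compound 1 to compound 2 (0.67 log units; beyond the scatter) was observed in this assay, a step of similar size is expected from compound 3 to compound 4, namely a 4.3-fold higher number from compound 3 to compound 4 (0.64 log units; beyond the scatter). Compound 4 is therefore estimated at 95000 nM in this assay, with a range from 40000 nM to 220000 nM.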

Compound 4, half-maximal inhibitory concentration: 46000 nM
Estimate against measurement, compound 4: 2.1-fold (0.31 log units) above, within the range that was stated.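

In this assay, 2,4-dichlorophenyl in place of 4-methylphenyl on the core bearing cyanosulfanyl gives a 2.1-fold higher number from compound 3 to compound 4 (0.32 log units; beyond the scatter), and this step cannot be told apart from the one seen on the core bearing formyl: the same change on two cores in this assay, a 4.6-fold higher number (0.67 log units; beyond the scatter) from compound 1 to compound 2 and a 2.1-fold higher number (0.32 log units; beyond the scatter) from compound 3 to compound 4, 2.2-fold (0.35 log units) apart, within the scatter of two such steps. Cyanosulfanyl in place of formyl, with 2,4-dichlorophenyl present, gives a 1.7-fold lower number from compound 2 to compound 4 (0.23 log units; within the scatter), and this step likewise cannot be told apart from its counterpart with 4-methylphenyl present: the same change on two cores in this assay, a 1.3-fold higher number (0.11 log units; within the scatter) from compound 1 to compound 3 and a 1.7-fold lower number (0.23 log units; within the scatter) from compound 2 to compound 4, 2.2-fold (0.35 log units) apart, within the scatter of two such steps. Each change therefore carries over between these two closely related cores within the scatter, but this rests on a single pair of steps per change and does not show that either change would carry over to other cores in the series, nor does it give any reason for the steps.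

The compounds shown leave open how an amine or a carboxylic acid in place of formyl or cyanosulfanyl would read in this assay. They also leave open whether a phenyl ring carrying a single chlorine or a methoxy group would follow the step seen with 2,4-dichlorophenyl.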